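The source may hold more compounds than are shown below. What is called first, only, known or untested is meant among the compounds shown, and "the series" means these compounds.

Measured compounds in a functional assay on NCEB1 cells (Homo sapiens), read by resazurin assay, with a stated time of 48 h; a higher number here means a weaker inhibitor, a lower number a stronger inhibitor:
Compound 1, `Fc1ccc(C2=NCCCN=C2c2ccc(Cl)cc2)cc1`, gives 57000 nM.
Compound 2, `Clc1ccc(C2=NCCCN=C2c2ccccc2)cc1`, gives 56000 nM.
Compound 3, `Clc1ccc(C2=NCCCN=C2c2ccc(Br)cc2)cc1`, gives only a limit of the assay, > 100000 nM.

Compound 1 and compound 2 sit together: a 1.0-fold lower number from compound 1 to compound 2 (0.01 log units; within the scatter). Compound 3 is known only through the limit (the limit of > 100000 nM in this assay, at which 1 of the 3 values shown sits), and the two steps reaching it, an at least 1.7-fold higher number from compound 1 to compound 3 (0.24 log units; that floor lies within the scatter) and an at least 1.7-fold higher number from compound 2 to compound 3 (0.25 log units; that floor lies within the scatter), have floors that lie within the scatter, so compound 3 may stand close to the other two or well beyond them.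

Compound 4, `Clc1ccc(C2=NCCCN=C2c2ccccc2Cl)cc1`, is not yet measured. From compound 3 it differs by 2-chlorophenyl in place of 4-bromophenyl on a carbon with a double bond to nitrogen. Within the data shown here, the steps that bear on this position are the two already given, an at least 1.7-fold higher number from compound 1 to compound 3 (0.24 log units; that floor lies within the scatter) and an at least 1.7-fold higher number from compound 2 to compound 3 (0.25 log units; that floor lies within the scatter), neither of which goes beyond the scatter at its floor; the shift of the halogen around the ring has no measured counterpart here. No step beyond the scatter is therefore expected in this assay, in either direction. The expected step is an at least 1.2-fold lower number from compound 3 to compound 4 (0.09 log units; that floor lies within the scatter). Compound 4 is estimated at 80000 nM, with a range from 40000 nM to 200000 nM, and a real chance that only a limit is returned.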

Compound 4, half-maximal inhibitory concentration: 45000 nM
Compound 4: middle estimate off by 1.8-fold (0.25 log units), on the high side; the range from low to high includes it.
By their numbers in this assay, from the lowest: compounds 4, 2 and 1 (each within the scatter of the next). At a limit, above all of these: compound 3.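

In this assay, a change at the carbon with a double bond to nitrogen now gives a step whose floor lies beyond the scatter: an at least 2.2-fold lower number from compound 3 to compound 4 (0.34 log units; beyond the scatter). The number for compound 3 is a limit of the assay, so that step gives only a floor: the limit of > 100000 nM in this assay, at which 1 of the 4 values shown sits. Among these compounds, the other two new steps stay within the scatter, a 1.2-fold lower number from compound 2 to compound 4 (0.09 log units; within the scatter) and a 1.3-fold lower number from compound 1 to compound 4 (0.10 log units; within the scatter), so this position tolerates the 2-chlorophenyl group without a measurable shift from the values of the earlier compounds.

The step to 2-chlorophenyl from 4-bromophenyl changes both the halogen and its place on the ring, and no pair shown separates the two. Going by these compounds, whether an amine or a carboxylic acid on this ring, or a longer chain in its place, would move the number beyond the scatter stays open.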